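This account rests on a few compounds, and the source may have more. Where it says the series, first, only, none or still open, it means among the compounds named here.

Measured so far:
- compound 1 `Cc1cc(-c2ccnc(C(F)F)c2)ncc1OC[C@@](C)(N)CC(C)C`: 1.4 nM
- compound 2 `COC(=O)Nc1cc(-c2cc(Cl)c(OC[C@@](C)(N)CC(C)C)cn2)ccn1`: 1.1 nM
- compound 3 `CC(C)C[C@H](N)COc1ccc(-c2ccnc(NCc3ccccc3)c2)cc1`: 127 nM

In an assay on isolated protein for inhibition of AP2-associated protein kinase 1 (Homo sapiens), with a stated time of 3 h, in the presence of a further agent that is not named here (on this read-out higher numbers stand for weaker inhibition and lower numbers for stronger inhibition), compound 3 stands highest of the three numbers; compound 1 gives 1.4 nM and compound 2 gives 1.1 nM, both far below it and beyond the scatter. Compound 4 `CC(C)C[C@H](N)COc1ccc(-c2ccnc(N)c2)cc1` is not yet measured. It differs from compound 3 in one place: hydrogen in place of benzyl on a nitrogen on an aromatic ring. For the measured compounds named here, no step between measured compounds covers this change, and compounds 1 and 2 share neither the core nor this group with compound 3, so the measured numbers do not bear on it directly. The step in this assay is expected to be small and toward a lower number, possibly within the scatter; the expected step is a 2.1-fold lower number from compound 3 to compound 4 (0.33 log units; beyond the scatter). Compound 4 is estimated at 60 nM, with a range from 15 nM to 250 nM.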

Compound 4, half-maximal inhibitory concentration: 21 nM
Compound 4: middle estimate off by 2.9-fold (0.46 log units), on the high side; the range from low to high includes it.
By their numbers in this assay, from the lowest: compounds 2 and 1 (each within the scatter of the next); then compound 4; then compound 3.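

In this assay, for the compounds shown here, replacing benzylamino with amino gives (a 6.0-fold lower number from compound 3 to compound 4 (0.78 log units; beyond the scatter)), the first single-place step. On this core, the benzyl on the nitrogen on an aromatic ring is therefore not needed for inhibition, and the unsubstituted amino group gives the lower number. No measurement at hand accounts for the size of this step.

Open, as far as these compounds go, is how a smaller group on that nitrogen, such as methyl or acetyl, would compare with hydrogen and benzyl. Also open, from the compounds shown here alone, is whether the same change gives a similar step on the cores of compound 1 and compound 2.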